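This account rests on a few compounds, and the source may have more. Where it says the series, first, only, none or still open, it means among the compounds named here.

This study follows a small set of compounds that share one core and were tested in a functional assay on HEK293 cells for agonist activity at G-protein coupled receptor 39 (Mus musculus), read by inositol phosphate accumulation; on this read-out lower numbers stand for an effect already at smaller amounts and higher numbers for an effect only at larger amounts of compound. For the measured compounds named here, compound 1 `CNc1nc(NCc2ccc(N(C)C(C)=O)cc2)cc(-c2ccccn2)n1` gives 2610 nM in this assay, the highest of the three numbers measured so far. Compound 2 `CNc1nc(NC2(c3ccc(Cl)cc3)CCC2)cc(-c2ccccn2)n1` gives 34 nM in this assay, and compound 3 `CNc1nc(NCc2ccc(Cl)cc2Cl)cc(-c2ccccn2)n1` gives 0.5 nM in this assay; both gaps to compound 1 lie well beyond the usual scatter, so compound 1 is the weakest of the three on this read-out. Compound 4 `CNc1nc(NCc2ccc(OC(F)(F)F)cc2)cc(-c2ccccn2)n1` has not yet been measured. It differs from compound 1 in one place: trifluoromethoxy in place of acetyl(methyl)amino on an aromatic carbon. Going by the values given here, no two measured compounds differ in just one place, so no directly comparable step exists. Still, a clear move toward lower numbers is expected, because compound 3 reaches 0.5 nM and compound 2 reaches 34 nM with other groups in place of the acetyl(methyl)amino. The expected step is a 26-fold lower number from compound 1 to compound 4 (1.42 log units; beyond the scatter). For compound 4 the estimate in this assay is 100 nM, with a range from 15 nM to 700 nM.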

Compound 4, half-maximal effective concentration: 7 nM
Compound 4: middle estimate off by 14-fold (1.15 log units), on the high side; measured number outside the range, below it.
By their numbers in this assay, from the lowest: compound 3; then compound 4; then compound 2; then compound 1.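

In this assay, putting trifluoromethoxy in place of acetyl(methyl)amino, on an aromatic carbon para to a large group, gives a 370-fold lower number from compound 1 to compound 4 (2.57 log units; beyond the scatter), a large step well beyond the usual scatter. For the compounds shown here, this is the first pair in the set that differs in only one place, so the gap can be tied to this single exchange, even though the two groups match in their counts of heavy atoms, hydrogen-bond donors and hydrogen-bond acceptors. Nothing shown here explains the size of the step.

Going by these compounds, it remains open whether other groups in this place, such as methoxy, an amine or a carboxylic acid, would give a similar step. On these data alone, it is also open whether the exchange would have the same effect if the methylamino group on the shared core were replaced by ethylamino.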